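The compounds below may be only part of what the source reports. "The series", "measured", "known", "first", "only" and "open" are said of these compounds alone.

Two compounds of a shared core have been characterised in a physicochemical assay for lipophilicity; a higher number here means a more lipophilic compound, a lower number a more polar compound. Compound 1 `C[C@H]1CC[C@@H]2[C@@H](OC(=O)[C@]23CC(c2ccc(N(C)C)cc2)=NO3)[C@]2(C)C(=O)C=C[C@@]12O` gives 1.51. Compound 2 `C[C@H]1CC[C@@H]2[C@@H](OC(=O)[C@]23CC(c2ccc(Br)cc2)N(c2ccccc2)O3)[C@]2(C)C(=O)C=C[C@@]12O` gives 4, the higher of the two readings, and its gap to compound 1 lies well beyond the scatter of the measurement.

Compound 3 `C[C@H]1CC[C@@H]2[C@@H](OC(=O)[C@]23CC(c2cccc(F)c2)N(c2ccccc2)O3)[C@]2(C)C(=O)C=C[C@@]12O` has not yet been measured in this assay. It differs from compound 2 in one place: 3-fluorophenyl in place of 4-bromophenyl on a saturated ring carbon. Going by the values given here, no measured pair in this set shows the effect of such an exchange, so the expectation rests on the value of compound 2 alone. Compound 3 is expected to read somewhat lower than compound 2, a step from compound 2 to compound 3 of a number 0.70 log units lower from compound 2 to compound 3 (beyond the scatter), a change beyond the scatter but far smaller than the gap separating compound 2 from compound 1. For compound 3 the estimate in this assay is 3.3, with a likely range from 2.8 to 3.8.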

Compound 3, partition coefficient: 3.35
The estimate for compound 3 lay 0.05 log units below the measured number, and the stated range covers the measured number.
By their numbers in this assay, from the lowest: compound 1; then compound 3; then compound 2.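

Going by these compounds alone, this is the first comparison in the set that differs in one place: in this assay, 3-fluorophenyl in place of 4-bromophenyl on a saturated ring carbon gives a number 0.65 log units lower from compound 2 to compound 3 (beyond the scatter). The reading at this position therefore responds to the substituted phenyl group, although both groups have the same counts of heavy atoms, hydrogen-bond donors and hydrogen-bond acceptors. Nothing available here accounts for the size of this step.

The exchange alters both the halogen and where it sits on the phenyl ring, and the compounds shown do not separate these two changes, which 4-fluorophenyl or 3-bromophenyl could do. Also open, going by these compounds, is how the reading would move with an amine or a carboxylic acid on that phenyl ring.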